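Fluoro added to the aromatic ring of compound 1

This account rests on a few compounds, and the source may have more. Where it says the series, first, only, none or still open, it means among the compounds named here.

Measured values in a functional assay on NCI-H1299 cells (Homo sapiens) for inhibition, read by CCK-8 assay, with a stated time of 72 h, tested at 10 uM (on this read-out lower numbers stand for less inhibition of growth and higher numbers for more inhibition of growth at the one concentration tested), are as follows.
- compound 1 `CN(C)C(=O)c1cc2cnc(Nc3ccc(NC(=O)C4(C(=O)Nc5ccc(F)cc5)CC4)cc3)nc2n1C1CCCC1` gives 90.8%
- compound 2 `Cc1ccc(NC(=O)C2(C(=O)Nc3ccc(Nc4ncc5cc(C(=O)N(C)C)n(C6CCCC6)c5n4)cc3)CC2)cc1` gives 84.5%

Compound 1 carries the top number of these two, but the gap to compound 2 stays within the scatter (a number 6.3 percentage points lower from compound 1 to compound 2 (within the scatter)). Compound 3 `CN(C)C(=O)c1cc2cnc(Nc3ccc(NC(=O)C4(C(=O)Nc5ccc(F)cc5)CC4)cc3F)nc2n1C1CCCC1` has fluoro in place of hydrogen on an aromatic carbon of compound 1, ortho to a large group and meta to a large group (fluoro in place of hydrogen on an aromatic carbon). Going by the values given here, no measured step touches this carbon. Among the compounds with values here, the one measured step, a methyl in place of fluoro on an aromatic carbon elsewhere, bears on it only loosely, and it gives no ground to expect a change beyond the scatter in this assay. The estimated change is a number 5.8 percentage points lower from compound 1 to compound 3 (within the scatter). Compound 3 is expected at 85%, with an estimated range from 68% to 98%.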

Compound 3, percent growth inhibition at one concentration: 82.6%
The estimate for compound 3 lay 2.4 percentage points above the measured number, and the stated range covers the measured number.
By their numbers in this assay, from the lowest: compounds 3, 2 and 1 (each within the scatter of the next).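

In this assay, fluoro in place of hydrogen on an aromatic carbon, ortho to a large group and meta to a large group, gives a number 8.2 percentage points lower from compound 1 to compound 3 (within the scatter), so at this carbon the change cannot be told from the scatter. Going by these compounds alone, the earlier step concerned a different aromatic carbon, which makes this the only reading at this position, and it shows that this ring tolerates fluoro here without a change beyond the scatter at the one concentration tested. No supporting measurement bears on this result or offers an explanation for it.

Going by these compounds, whether methoxy, an amine or a carboxylic acid on this carbon would move the growth inhibition beyond the scatter stays open. Also open, on these data alone, is whether fluoro on the remaining carbons of this ring would behave as it does here.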